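Chloro for Methyl: Expected Gain in Seizure Protection

This account rests on a few compounds, and the source may have more. Where it says the series, first, only, none or still open, it means among the compounds named here.

Measured compounds:
Compound 1, `CCC(C(=O)N1CCN(c2cccc(C)c2)CC1)N1C(=O)CCC1=O`, gives 0%.
Compound 2, `CCC(C(=O)N1CCN(c2cccc(Cl)c2)CC1)N1C(=O)CCC1=O`, gives 25%.
Compound 3, `Cc1cccc(N2CCN(C(=O)C(C)N3C(=O)CCC3=O)CC2)c1`, gives 0%.

All three were tested in a functional assay on the whole organism (strain Swiss) with Mus musculus as the target, in the maximal electroshock model, with a stated time of 2 h, at a dose of 300 mg/kg by the intraperitoneal route; a higher number here means a stronger effect of the compound at the dose given, a lower number a weaker effect. Compound 2 differs from compound 1 by chloro in place of methyl on an aromatic carbon, and this change raised the read-out: a number 25 percentage points higher from compound 1 to compound 2 (beyond the scatter). Compound 3 differs from compound 1 by hydrogen in place of methyl on a saturated chain carbon, two bonds along the chain from an amide-type nitrogen in a ring and a carbonyl carbon, and here the read-out did not move: no change at the digits printed from compound 1 to compound 3 (within the scatter). Compound 1 and compound 3 thus sit level at the bottom of the set, and compound 2 stands apart above them.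

Compound 4, `CC(C(=O)N1CCN(c2cccc(Cl)c2)CC1)N1C(=O)CCC1=O`, has not yet been tested in this assay. It differs from compound 3 by chloro in place of methyl on an aromatic carbon. This is the same change as from compound 1 to compound 2, made this time on the core of compound 3 rather than on the core of compound 1; the two cores differ by hydrogen in place of methyl on a saturated chain carbon, two bonds along the chain from an amide-type nitrogen in a ring and a carbonyl carbon, a difference that on its own left the read-out unchanged. For the measured compounds named here, since the one measured instance of this change gave a number 25 percentage points higher from compound 1 to compound 2 (beyond the scatter), a rise of similar size is expected here, with the caution that a single prior example is a thin base and the step may turn out smaller or larger. The expected step is a number 20 percentage points higher from compound 3 to compound 4 (beyond the scatter). Compound 4 is therefore estimated at 20%, with a plausible range from 0% to 50%.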

Compound 4, a percentage reported as activity, at one dose (the size of the read-out at that dose, not a potency): 50%
Beside the measured number, compound 4's estimate is 30 percentage points below it, and the stated range covers the measured number.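

In this assay, the change from 3-methylphenyl to 3-chlorophenyl raised the read-out on both cores, with a number 50 percentage points higher from compound 3 to compound 4 (beyond the scatter), so the direction carried over but the size did not: the same change on two cores in this assay, a number 25 percentage points higher (beyond the scatter) from compound 1 to compound 2 and a number 50 percentage points higher (beyond the scatter) from compound 3 to compound 4, 25 percentage points apart, beyond the scatter of two such steps

Seen from the other side, hydrogen in place of the chain methyl did nothing measurable to the 3-methylphenyl compounds, yet the same change on the 3-chlorophenyl compounds gave a number 25 percentage points higher from compound 2 to compound 4 (beyond the scatter), and so the two changes do not simply add up: the same change on two cores in this assay, no change at the digits printed (within the scatter) from compound 1 to compound 3 and a number 25 percentage points higher (beyond the scatter) from compound 2 to compound 4, 25 percentage points apart, beyond the scatter of two such steps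

This shows that, among these four compounds, the gain from chloro depends on the rest of the molecule and that the effect of one change cannot be copied unaltered to another core; it does not show why the two changes interact, nor whether the same would hold at another dose, since each number is the size of an effect at one dose and not a potency.

The compounds shown leave open how other groups on the same aromatic carbon, such as fluoro, trifluoromethyl or methoxy, would behave on these two cores. They also leave open whether a longer chain, such as propyl in place of the chain methyl, would widen or narrow the gap between the methyl and chloro compounds.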